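Compound 1 to compound 4: working notes on the series

The source may hold more compounds than are shown below. What is called first, only, known or untested is meant among the compounds shown, and "the series" means these compounds.

- compound 1 `C=C1C(=O)O[C@@H]2CC(C)=C([C@@H](C)CCCOC(C)=O)[C@@H](OC(=O)COc3cccc(C(C)=O)c3)[C@H]12`: 46100 nM
- compound 2 `C=C1C(=O)O[C@@H]2CC(C)=C([C@@H](C)CCCOC(C)=O)[C@@H](OC(=O)COc3ccc([N+](=O)[O-])cc3[N+](=O)[O-])[C@H]12`: > 100000 nM, a limit
- compound 3 `C=C1C(=O)O[C@@H]2CC(C)=C([C@@H](C)CCCOC(C)=O)[C@@H](OC(=O)COc3ccc4c(CC)noc4c3)[C@H]12`: 21200 nM

In a functional assay on SGC-7901 cells (Homo sapiens) for cytotoxicity, read by sulforhodamine B assay, with a stated time of 72 h (on this read-out lower numbers stand for stronger inhibition and higher numbers for weaker inhibition), compound 1 gives 46100 nM, the higher of the two actual numbers, and compound 3 gives the lower at 21200 nM. For compound 2 the reading is only a limit: the limit of > 100000 nM in this assay, at which 1 of the 3 values shown sits.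

Compound 4 `C=C1C(=O)O[C@@H]2CC(C)=C([C@@H](C)CCCOC(C)=O)[C@@H](OC(=O)c3cccc(F)c3)[C@H]12` has 3-fluorophenyl in place of (3-acetylphenoxy)methyl on a carbonyl carbon.

The nearest measured changes are an at least 2.1-fold higher number from compound 1 to compound 2 (0.33 log units; beyond the scatter) and a 2.2-fold lower number from compound 1 to compound 3 (0.34 log units; beyond the scatter). These modest steps run in opposite directions, so neither sets a direction for this change. The expected result in this assay is a 1.5-fold lower number from compound 1 to compound 4 (0.19 log units; within the scatter), with no shift beyond the scatter expected. Compound 4 is estimated at 30000 nM, with an expected range of 10000 nM to 90000 nM.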

Compound 4, half-maximal inhibitory concentration: 12900 nM
Compound 4: the middle estimate sits 2.3-fold (0.37 log units) above what was measured; low and high end bracket the measured number.
By their numbers in this assay, from the lowest: compounds 4 and 3 (each within the scatter of the next); then compound 1. At a limit, above all of these: compound 2.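

In this assay, 3-fluorophenyl in place of (3-acetylphenoxy)methyl gives a 3.6-fold lower number from compound 1 to compound 4 (0.55 log units; beyond the scatter), on the same carbonyl carbon. The earlier compounds shown here all carried an aryloxymethyl group here, whereas compound 4 shows that a smaller aryl group, without that ether oxygen, also gives a measurable reading. Nothing at hand accounts for this step.

Open, on these data alone, is what the fluorine contributes, set against a plain phenyl. Also open, as far as these compounds go, is whether an aminomethyl group or a longer alkyl chain on this carbonyl carbon would keep the reading.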